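Swapping a bromophenyl for a dichlorophenyl in cytotoxicity

The source may hold more compounds than are shown below. What is called first, only, known or untested is meant among the compounds shown, and "the series" means these compounds.

Compound 1 `COc1cc(/C=C2\CN(C)C/C(=C\c3ccc(Br)cc3)C2=O)cc(OC)c1OC` and compound 3 `CN1C/C(=C\c2ccc(Br)cc2)C(=O)/C(=C/c2cccc([N+](=O)[O-])c2)C1` share one arm, a 4-bromophenyl, and differ in the rest of the molecule; the difference between their two cores is not broken down here. In a functional assay on HeLa cells (Homo sapiens) for cytotoxicity, read by MTT assay, with a stated time of 24 h (a higher number here means a weaker inhibitor, a lower number a stronger inhibitor), compound 1 gives 11900 nM. In this assay compound 3 gives 11900 nM, the same as compound 1 at the digits recorded.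

Compound 2 `COc1cc(/C=C2\CN(C)C/C(=C\c3ccc(Cl)cc3Cl)C2=O)cc(OC)c1OC` differs from compound 1 by one change: 2,4-dichlorophenyl in place of 4-bromophenyl on a double-bonded chain carbon bound to a double-bonded ring carbon. In this assay compound 2 reaches only a limit of the assay, > 20000 nM. The measured step is an at least 1.6-fold higher number from compound 1 to compound 2 (0.22 log units; that floor lies within the scatter); the result is a limit, so the size of this step is known only as a floor, as the record the limit of > 20000 nM in this assay, at which 1 of the 3 values shown sits, shows.

Compound 4 `CN1C/C(=C\c2cccc([N+](=O)[O-])c2)C(=O)/C(=C/c2ccc(Cl)cc2Cl)C1` has not been measured. It carries the same change on the core of compound 3: 2,4-dichlorophenyl in place of 4-bromophenyl on a double-bonded chain carbon bound to a double-bonded ring carbon. The place of the change is the same in both pairs, so the second step is expected to resemble the first.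

Compound 4 is therefore expected to give about 22000 nM. For compound 4 the expected range runs from 10000 nM to 50000 nM. The expected step of a 1.8-fold higher number from compound 3 to compound 4 (0.27 log units; within the scatter) rests on the fact that the earlier pair showed an at least 1.6-fold higher number from compound 1 to compound 2 (0.22 log units; that floor lies within the scatter), and it may well end as a limit again rather than a number.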

Compound 4, half-maximal inhibitory concentration: 8900 nM
Beside the measured number, compound 4's estimate is 2.5-fold (0.39 log units) above it; measured number below the stated range.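

In this assay, among the compounds shown here, 2,4-dichlorophenyl in place of 4-bromophenyl gives a 1.3-fold lower number from compound 3 to compound 4 (0.13 log units; within the scatter), so on this core the change leaves no step that stands clear of the ordinary spread of repeated measurements. Set beside the earlier pair, the two results do not settle whether the change behaves alike on the two cores: the same change on two cores in this assay, an at least 1.6-fold higher number (0.22 log units; that floor lies within the scatter) from compound 1 to compound 2 and a 1.3-fold lower number (0.13 log units; within the scatter) from compound 3 to compound 4; the limit leaves it open whether they differ. The series therefore shows that the change does not make a clear difference on the core of compound 3, but it does not show that the effect carries over unchanged from one core to the other, nor that it differs between them.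

The compounds shown leave open how the true size of the step to compound 2 compares, as that compound's result is a limit and not a number. They also leave open what happens when the arm carries something other than a halogen, such as an amine or a carboxylic acid, in place of the bromine or the two chlorines.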